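The compounds below may be only part of what the source reports. "The series", "measured", "known", "first", "only" and "open" are said of these compounds alone.

In a functional assay on CHO-RD-HGA16 cells for agonist activity at Orexin/Hypocretin receptor type 1 (Homo sapiens), read by fluorescence and calcium flux, with a stated time of 30 min (a higher number here means that more compound is needed for the effect, a lower number that less compound is needed), compound 3 `COc1ccc(-c2cccc(C(=O)N(C)CCN(C)C)c2)cc1S(=O)(=O)Nc1cccc(NCCNC(=O)c2cccc(C)c2)c1` gives 638 nM. Compound 1 `COc1ccc(-c2cccc(C(=O)N(C)C)c2)cc1S(=O)(=O)Nc1cccc(N2CCN(C(=O)c3cccc(C)c3)CC2)c1` returns only a limit of the assay, > 10000 nM. Compound 2 `COc1ccc(/C=C/C(=O)N(C)C)cc1S(=O)(=O)Nc1cccc(NCCNC(=O)c2cccc(C)c2)c1` likewise returns only a limit, > 10000 nM. Among the compounds with values here, compound 3 therefore holds the only actual number among the three values reported, the other two sitting at the limit of > 10000 nM in this assay, at which 2 of the 3 values shown sit. Compound 4 `COc1ccc(-c2cccc(C(=O)NCc3ccccn3)c2)cc1S(=O)(=O)Nc1cccc(NCCNC(=O)c2cccc(C)c2)c1` carries ((pyridin-2-yl)methyl)amino in place of (2-(dimethylamino)ethyl)(methyl)amino on a carbonyl carbon. Within the data shown here, no pair of measured compounds differing in one place is available here to size such a step, so the expectation rests on the run of values alone. Compound 4 is expected to come out weaker, the step of a 3.9-fold higher number from compound 3 to compound 4 (0.59 log units; beyond the scatter) being estimated as a loss beyond the usual scatter. Compound 4 is accordingly estimated at 2500 nM, within a range of 600 nM to 10000 nM.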

Compound 4, half-maximal effective concentration: > 10000 nM
Compound 4: no number, only a limit; the forecaster's own chance of this, stated with the estimate: 35%; middle value at least 4.0-fold (0.60 log units) away from the limit.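

Within the data shown here, this is the first change in one place that can be read: ((pyridin-2-yl)methyl)amino in place of (2-(dimethylamino)ethyl)(methyl)amino on a carbonyl carbon gives an at least 15-fold higher number from compound 3 to compound 4 (1.19 log units; beyond the scatter) in this assay. Compound 4 returns > 10000 nM, which is a limit and not a number. Compound 3 thus remains the only compound with an actual value, and compound 4 joins the others at the limit: the limit of > 10000 nM in this assay, at which 3 of the 4 values shown sit.

The compounds shown leave open whether (2-(dimethylamino)ethyl)amino, which has the amide hydrogen but no ring, would keep a measurable value. They also leave open how a longer chain ending in dimethylamino would read at this position.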